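The compounds below may be only part of what the source reports. "The series", "measured", "known", "first", "only" and "open" are said of these compounds alone.

Compounds 1, 2 and 3 share one core and differ only in the ring attached to the sulfur: compound 1 `CC(C)[C@H](NC(=O)COc1cccc2ccccc12)C(=O)N[C@@H](CC(=O)O)C(=O)CSc1nc(-c2ccccc2)no1`, compound 2 `CC(C)[C@H](NC(=O)COc1cccc2ccccc12)C(=O)N[C@@H](CC(=O)O)C(=O)CSc1nnnn1-c1ccccc1` and compound 3 `CC(C)[C@H](NC(=O)COc1cccc2ccccc12)C(=O)N[C@@H](CC(=O)O)C(=O)CSc1nnnn1C`. In a functional assay on Jurkat cells (Homo sapiens) for inhibition (on this read-out higher numbers stand for weaker inhibition and lower numbers for stronger inhibition), compound 1 gives 102000 nM and compound 2 gives 153000 nM. For compound 3 only a limit is known, > 200000 nM, so it sits at the limit of > 200000 nM in this assay, at which 1 of the 3 values shown sits. The change to compound 4 `CC(C)[C@H](NC(=O)COc1cccc2ccccc12)C(=O)N[C@@H](CC(=O)O)C(=O)CSc1nc2ccccc2s1` is 1,3-benzothiazol-2-yl in place of 1-methyl-1H-tetrazol-5-yl on a sulfur. The measured steps that bear on it are all small: a 1.5-fold higher number from compound 1 to compound 2 (0.18 log units; within the scatter), an at least 1.9-fold higher number from compound 1 to compound 3 (0.29 log units; that floor lies within the scatter) and an at least 1.3-fold higher number from compound 2 to compound 3 (0.11 log units; that floor lies within the scatter). Because the ring swaps an at least 1.9-fold higher number from compound 1 to compound 3 (0.29 log units; that floor lies within the scatter) and an at least 1.3-fold higher number from compound 2 to compound 3 (0.11 log units; that floor lies within the scatter) stayed within the scatter, only a modest step back toward a measurable number is expected, an at least 1.6-fold lower number from compound 3 to compound 4 (0.22 log units; that floor lies within the scatter). Compound 4 is therefore estimated at 120000 nM, between 50000 nM and 300000 nM.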

Compound 4, half-maximal inhibitory concentration: > 200000 nM
Compound 4 gave a limit, no number; the forecaster's own chance of this, stated with the estimate: 25%; middle value at least 1.6-fold (0.22 log units) from the limit.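

Compound 4, with 1,3-benzothiazol-2-yl on the sulfur, also gives only a limit in this assay: > 200000 nM. The step between compound 3 and compound 4 cannot be read, because both rest at the same limit: the limit of > 200000 nM in this assay, at which 2 of the 4 values shown sit. Only floors exist against the phenyl-bearing rings, an at least 1.3-fold higher number from compound 2 to compound 4 (0.11 log units; that floor lies within the scatter) and an at least 1.9-fold higher number from compound 1 to compound 4 (0.29 log units; that floor lies within the scatter), so 1,3-benzothiazol-2-yl shows no sign of stronger inhibition here. As far as these compounds go, how an amine or a longer chain on this sulfur would read remains open. So does the true size of the numbers behind the limits of compound 3 and compound 4.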